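The source may hold more compounds than are shown below. What is called first, only, known or untested is meant among the compounds shown, and "the series" means these compounds.

Measured so far in a functional assay on MCF7 cells (Homo sapiens) for inhibition, read by MTT assay, with a stated time of 48 h; on this read-out lower numbers stand for stronger inhibition and higher numbers for weaker inhibition:
compound 1 `COc1cc(N(Cc2ccc(Br)cc2)S(=O)(=O)c2ccc(C)cc2)cc(OC)c1OC` gives 10900 nM
compound 2 `COc1cc(N(Cc2csc3ccc(Cl)cc23)S(=O)(=O)c2ccc(C)cc2)cc(OC)c1OC` gives 8950 nM
compound 3 `Cc1ccc(S(=O)(=O)N(Cc2nc3ccccc3[nH]2)c2ccc(F)cc2)cc1` gives > 50000 nM

For the measured compounds named here, the only step between two measured compounds that differ in one place is a 1.2-fold lower number from compound 1 to compound 2 (0.09 log units; within the scatter), a swap on the benzylic carbon that leaves the number within the scatter. For compound 3 the value is a limit of the assay and not a number, and it sits at the limit of > 50000 nM in this assay, at which 1 of the 3 values shown sits. Compound 3 therefore stands at the weak end of the numbers shown, with no number to rank it against compound 1 or compound 2.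

Compound 4 `COc1ccc(N(Cc2nc3ccccc3[nH]2)S(=O)(=O)c2ccc(C)cc2)cc1` is not yet measured. It differs from compound 3 by methoxy in place of fluoro on an aromatic carbon, para to a large group. No measured step touches this position or this change; the one step shown, from compound 1 to compound 2, concerns a different part of the molecule and was itself within the scatter. Nothing shown points to a step beyond the scatter in either direction in this assay.

Compound 4 is expected to stay near the limit, with an estimated step of a number no higher from compound 3 to compound 4 (the limit leaves the size open). The estimate for compound 4 is 50000 nM, between 20000 nM and 120000 nM, and a limit rather than a number is the more likely outcome.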

Compound 4, half-maximal inhibitory concentration: > 50000 nM
Compound 4: no number, only a limit; the forecaster's own chance of this, stated with the estimate: 60%; the middle value lies on the limit itself.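

For the compounds shown here, compound 4, like compound 3, ends at a limit and not a number, so no step between the two can be read: the limit of > 50000 nM in this assay, at which 2 of the 4 values shown sit. The compounds shown leave open whether 4-methoxyphenyl in place of 4-fluorophenyl changes the inhibition at all in this assay.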